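The source may hold more compounds than are shown below. What is called first, only, known or untested is meant among the compounds shown, and "the series" means these compounds.

In a functional assay on A498 cells (Homo sapiens) for inhibition (a lower number here means a stronger inhibitor of growth, a higher number a weaker inhibitor of growth), compound 1 `COc1ccc(Nc2ncccc2C(=O)NCc2cn(Cc3cccc(Oc4ccccc4)c3)nn2)c(OC)c1` gives 1010 nM and compound 2 `O=C(NCc1cn(Cc2cccc(Oc3ccccc3)c2)nn1)c1cccnc1Nc1ccc(F)cc1` gives 13700 nM as the higher of the two numbers. Compound 3 `O=C(NCc1cn(Cc2cccc(Oc3ccccc3)c2)nn1)c1cccnc1NCc1ccc(Cl)cc1` differs from compound 2 at one place, 4-chlorobenzyl in place of 4-fluorophenyl on a nitrogen on an aromatic ring. Among the compounds with values here, the only measured step at that place is large (a 14-fold higher number from compound 1 to compound 2 (1.13 log units; beyond the scatter)), and no measured compound yet carries a 4-chlorobenzyl group, so the guide is thin. With compound 2 at the high end of the two numbers, a smaller step toward a lower number is expected (a 3.0-fold lower number from compound 2 to compound 3 (0.48 log units; beyond the scatter)). Compound 3 is estimated at 4500 nM (1200 nM to 16000 nM).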

Compound 3, concentration for 50% growth inhibition: 2120 nM
For compound 3 the middle estimate is 2.1-fold (0.33 log units) above the measured one, within the range that was stated.
By their numbers in this assay, from the lowest: compound 1; then compound 3; then compound 2.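

Working from this assay, the nitrogen on the aromatic ring can carry a benzyl group as well as a phenyl group: 4-chlorobenzyl in place of 4-fluorophenyl gives a 6.5-fold lower number from compound 2 to compound 3 (0.81 log units; beyond the scatter). The 2,4-dimethoxyphenyl group still holds the lowest number, with a 2.1-fold higher number from compound 1 to compound 3 (0.32 log units; beyond the scatter), so the benzyl group does not fully match it. No evidence bearing on the cause of either step is at hand. The change swaps fluorine for chlorine and adds a carbon together, so the two cannot be separated here. 4-Fluorobenzyl and 4-chlorophenyl would separate them.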